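The source may report more compounds than this note shows. Statements on the series, on what has been measured and on what is new or still open speak of the compounds shown alone.

Measured so far in an ADME assay on microsomes from liver (Mus musculus) for metabolic stability, read by LC-MS, using NADPH, with stated times of 15 min and 60 min, tested at 4.6 uM; on this read-out lower numbers stand for a shorter-lived compound and higher numbers for a longer-lived compound:

- Compound 1 `O=C(NCCCCc1ccccc1)n1c2c(oc1=O)CNCC2`: < 0.25 h (a limit of the assay, not a number)
- Compound 2 `CN1CCC(c2ccc3c(c2)oc(=O)n3C(=O)NCCCCc2ccc(F)cc2)CC1`: 0.5 h
- Compound 3 `CC(C)CN1CCC(c2ccc3c(c2)oc(=O)n3C(=O)NCCCCc2ccccc2)CC1`: 1 h

Compound 3 gives 1 h and compound 2 gives 0.5 h, two numbers that lie within the usual scatter of each other. Compound 1 has only a limit, so it cannot be ranked exactly against them.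

The next step starts from compound 3. Compound 4 `CN1CCN(c2ccc3c(c2)oc(=O)n3C(=O)NCCCCc2ccccc2)CC1=O` carries 4-methyl-3-oxopiperazin-1-yl in place of 1-isobutylpiperidin-4-yl on an aromatic carbon.

Within the data shown here, no measured step isolates this change. The expectation rests on compound 3 at 1 h and compound 2 at 0.5 h, which differ in more than one place yet stay within the scatter of each other. Only a modest shortening, no larger than the scatter, is therefore expected in this assay, and the estimated step is a 1.7-fold lower number from compound 3 to compound 4 (0.22 log units; within the scatter). The estimated half-life of compound 4 is 0.6 h, with an expected range from 0.25 h to 1.5 h.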

Compound 4, half-life: 0.5 h
Compound 4: middle estimate off by 1.2-fold (0.08 log units), on the high side; low and high end bracket the measured number.
By their numbers in this assay, from the lowest: compounds 2, 4 and 3 (each within the scatter of the next). At a limit, below all of these: compound 1.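

Among these compounds, the first change confined to this one aromatic carbon gives a 2.0-fold lower number from compound 3 to compound 4 (0.30 log units; within the scatter) in this assay. Here, 4-methyl-3-oxopiperazin-1-yl, a ring with 2 hetero atoms and a double bond outside aromatic rings, replaces 1-isobutylpiperidin-4-yl, a ring with 1 hetero atom, and the half-lives of the two compounds still cannot be told apart. Of the compounds shown, only compound 1 stands at a limit, and both compounds in this step give real numbers: the limit of < 0.25 h in this assay, at which 1 of the 4 values shown sits.

A single step at one position cannot show whether a morpholine ring, an open-chain amine or a carboxylic acid at this carbon would move the half-life beyond the scatter. It also leaves open whether the same swap would read alike on the fluorinated chain of compound 2.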